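The source may hold more compounds than are shown below. What is called first, only, known or untested is meant among the compounds shown, and "the series" means these compounds.

Compound 1 `Cc1cccc(Cc2cnc(CCc3ccc(-c4ccccc4C(=O)O)cc3)[nH]2)c1` gives 4310 nM in an in vitro functional assay on cells for agonist activity at Bombesin receptor subtype-3 (Homo sapiens), read by luminescence and calcium flux; on this read-out lower numbers stand for an effect already at smaller amounts and higher numbers for an effect only at larger amounts of compound. Compound 3 `O=C(O)c1ccccc1-c1ccc(CCc2ncc(Cc3cccc(F)c3F)[nH]2)cc1` gives 87 nM. Compound 2 `CCCCc1cnc(Cc2ccc(-c3ccccc3C(=O)O)cc2)[nH]1` gives only a limit, > 10000 nM, as recorded at the limit of > 10000 nM in this assay, at which 1 of the 3 values shown sits.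

Compound 1 holds the highest of the two numbers; its nearest neighbour is compound 3, reached by a 50-fold lower number from compound 1 to compound 3 (1.69 log units; beyond the scatter). That step exchanges one aryl group for another on the saturated chain carbon bound to an aromatic carbon and shows the position to be sensitive. Compound 4 `CC(C)CCc1cnc(CCc2ccc(-c3ccccc3C(=O)O)cc2)[nH]1` differs from compound 1 by isobutyl in place of 3-methylphenyl on a saturated chain carbon bound to an aromatic carbon. Among the compounds with values here, no measured step removes the ring at this position; compound 2, the one alkyl-bearing analogue, sits at the limit. Compound 4 is therefore expected to give a higher number than compound 1, a 2.1-fold higher number from compound 1 to compound 4 (0.32 log units; beyond the scatter), with a fair chance of a limit. Compound 4 is estimated at 9000 nM, within 3000 nM to 30000 nM.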

Compound 4, half-maximal effective concentration: 119 nM
For compound 4 the middle estimate is 76-fold (1.88 log units) above the measured one, outside the stated range (below it).
By their numbers in this assay, from the lowest: compounds 3 and 4 (each within the scatter of the next); then compound 1. At a limit, above all of these: compound 2.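

Isobutyl in place of 3-methylphenyl gives a 36-fold lower number from compound 1 to compound 4 (1.56 log units; beyond the scatter), so an aromatic ring is not required at this position for a low number. Isobutyl in place of 2,3-difluorophenyl gives a 1.4-fold higher number from compound 3 to compound 4 (0.14 log units; within the scatter), so among the three groups, only 3-methylphenyl stands apart. Nothing shown gives a cause for the high number of compound 1.

Still open, on these data alone, is how an amine or a longer chain would read in place of isobutyl on a saturated chain carbon bound to an aromatic carbon. Also open, as far as these compounds go, is how far the alkyl group can change before the number rises.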